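The source may report more compounds than this note shows. Statements on the series, on what has been measured and on what is new or still open speak of the compounds shown alone.

Values in a functional assay on A549 cells (Homo sapiens) for inhibition, read by MTT assay, with a stated time of 72 h; on this read-out higher numbers stand for weaker inhibition and lower numbers for stronger inhibition:
compound 1 `O=c1cc(Cn2cc(-n3ccc4cc(I)ccc43)nn2)c2ccc(O)cc2o1`: 28600 nM
compound 2 `Cc1ccc2c(Cn3cc(-n4ccc5cc(I)ccc54)nn3)cc(=O)oc2c1`: 34100 nM
compound 3 `Cn1c(-c2cn(Cc3cc(=O)oc4cc(O)ccc34)nn2)nc2ccccc21`: > 100000 nM

Compound 1 and compound 2 share a core and differ by methyl in place of hydroxy on an aromatic carbon; the step of a 1.2-fold higher number from compound 1 to compound 2 (0.08 log units; within the scatter) is within the scatter. For compound 3 the read-out is a limit of this assay and not a number, > 100000 nM, as noted in the limit of > 100000 nM in this assay, at which 1 of the 3 values shown sits. The difference between the cores of compound 1 and compound 3 is not broken down here.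

Compound 4 `Cc1ccc2c(Cn3cc(-c4nc5ccccc5n4C)nn3)cc(=O)oc2c1` is not yet measured in this assay. It differs from compound 3 by methyl in place of hydroxy on an aromatic carbon, the same change as from compound 1 to compound 2, at the same place. Because a 1.2-fold higher number from compound 1 to compound 2 (0.08 log units; within the scatter) is within the scatter, the step that the limit leaves unreadable from compound 3 to compound 4 is expected to be small as well. Compound 4 is therefore estimated at 120000 nM, between 40000 nM and 350000 nM, and a limit rather than a number is the more likely read-out.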

Compound 4, half-maximal inhibitory concentration: 16900 nM
Compound 4: the middle estimate sits 7.1-fold (0.85 log units) above what was measured; measured number outside the range, below it.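

In this assay, methyl in place of hydroxy on an aromatic carbon gives an at least 5.9-fold lower number from compound 3 to compound 4 (0.77 log units; beyond the scatter). The change therefore does not carry over from one core to the other with the same size: the same change on two cores in this assay, a 1.2-fold higher number (0.08 log units; within the scatter) from compound 1 to compound 2 and an at least 5.9-fold lower number (0.77 log units; beyond the scatter) from compound 3 to compound 4, at least 7.0-fold (0.84 log units) apart, beyond the scatter of two such steps. Going by these compounds, compound 3 is a limit of the assay and not a number, so the full size of the step stays unknown, and two cores cannot show which part of the core goes with the difference: the limit of > 100000 nM in this assay, at which 1 of the 4 values shown sits.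

The compounds shown hold only hydroxy or methyl at this place, which leaves open how an amine, a methoxy group or fluorine would read there. On these data alone, whether this change gives a step like either of these on a third core also remains open.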